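A few compounds are considered here, and "the series" means these few. Any claim that something is new, unique, unknown or untested is made for them only; others in the source may bear on it.

Measured compounds:
- compound 1 `CC(=O)O[C@H]1CC[C@]2(C)[C@H](CC[C@@](C)(O)[C@H]2CC[C@@H]2C(C)=CC[C@H]3[C@H](CC[C@]3(C)OC(C)=O)C2(C)C)OC1(C)C`: 26200 nM
- compound 2 `CC1=CC[C@H]2[C@H](CC[C@]2(C)O)C(C)(C)[C@@H]1CC[C@H]1[C@]2(C)CC[C@H](OC(=O)CCC(=O)O)C(C)(C)O[C@H]2CC[C@@]1(C)O`: 27900 nM
- compound 3 `CC1=CC[C@H]2[C@@H]1CC=C(C)[C@@H](CC[C@H]1[C@]3(C)CC[C@H](OC(=O)c4ccc(C)cc4)C(C)(C)O[C@H]3CC[C@@]1(C)O)C2(C)C`: 32700 nM

These three compounds share a common core and differ in the ester group attached to it. In a functional assay on MDA-MB-231 cells (Homo sapiens) for antiproliferative activity, read by MTT assay, with a stated time of 72 h (a lower number here means a stronger inhibitor, a higher number a weaker inhibitor), compound 1 gives 26200 nM, compound 2 gives 27900 nM and compound 3 gives 32700 nM. The three numbers sit close together: compound 2 stands second highest of the three, but its gaps to compound 1 and to compound 3 both fall within the scatter of repeated measurements, so no order among them can be read from the data.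

Compound 4 `CC1=CC[C@H]2[C@H](CC[C@]2(C)O)C(C)(C)[C@@H]1CC[C@H]1[C@]2(C)CC[C@H](OC(=O)c3ccccc3[N+](=O)[O-])C(C)(C)O[C@H]2CC[C@@]1(C)O` has not yet been measured in this assay. It is compound 2 with one change on the ester: 2-nitrophenyl in place of 2-carboxyethyl on a carbonyl carbon. For the measured compounds named here, no measured pair in this set differs in only one place, so there is no directly comparable step to lean on. What the data do show is that three quite different ester groups all land in the same narrow band, which gives no reason to expect the new ester to move the number beyond the scatter. The step expected a 1.1-fold higher number from compound 2 to compound 4 (0.03 log units; within the scatter) is therefore small, with no clear direction. For compound 4 the estimated value in this assay is 30000 nM, within a range of 12000 nM to 75000 nM.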

Compound 4, half-maximal inhibitory concentration: 38700 nM
Compound 4: the middle estimate sits 1.3-fold (0.11 log units) below what was measured; the range from low to high includes it.
By their numbers in this assay, from the lowest: compounds 1, 2, 3 and 4 (each within the scatter of the next).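

In this assay, for the compounds shown here, the exchange of 2-carboxyethyl for 2-nitrophenyl on a carbonyl carbon gives a 1.4-fold higher number from compound 2 to compound 4 (0.14 log units; within the scatter) and is the first comparison in this set in which only one place differs. The two groups are far from alike: an open chain with one hydrogen-bond donor is exchanged for a six-membered aromatic ring carrying no such donor, yet the two compounds cannot be told apart in this measurement. At this place, then, the exchange shows no effect that rises above the ordinary spread of repeated results, a firmer statement than the earlier comparison of compounds that differ in more than the one place could support, and no measurement bears on why this is so.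

As far as these compounds go, whether any group on this carbonyl carbon can move the number beyond the scatter remains open, for instance an amine at the end of the chain or a longer carbon chain. Also open, from the compounds shown here alone, is whether a simple phenyl ring without the nitro group would read the same as the 2-nitrophenyl ester of compound 4.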